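Sulfonyl for carbonyl on the compound 1 linker

The compounds below may be only part of what the source reports. "The series", "measured", "known", "first", "only" and "open" are said of these compounds alone.

Compound 1 `CN(C(=O)c1ccc(Br)cc1)c1ccc2[nH]c(-c3n[nH]c4ccccc34)cc2n1` is the anchor of this set. For the measured compounds named here, in a functional assay on HL-60 cells (Homo sapiens) for antiproliferative activity, read by MTT assay, with a stated time of 72 h (a lower number here means a stronger inhibitor, a higher number a weaker inhibitor), compound 1 gives 1080 nM, the lowest of the three numbers measured so far. Compound 2 `CN(C(=O)c1ccc([N+](=O)[O-])cc1)c1ccc2[nH]c(-c3n[nH]c4ccccc34)cc2n1` differs from it in one place only, nitro in place of bromo on an aromatic carbon; in this assay compound 2 gives 6800 nM, and the step is a 6.3-fold higher number from compound 1 to compound 2 (0.80 log units; beyond the scatter). Compound 3 `CN(C(=O)c1ccccc1)c1ccc2[nH]c(-c3n[nH]c4cc(C#N)ccc34)cc2n1` differs from compound 1 in two places at once, so only its value can be set beside it: in this assay compound 3 gives 6430 nM, a higher number than compound 1.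

Compound 4 `CN(c1ccc2[nH]c(-c3n[nH]c4ccccc34)cc2n1)S(=O)(=O)c1ccc(Cl)cc1` is not yet measured. It differs from compound 1 by (4-chlorophenyl)sulfonyl in place of (4-bromophenyl)carbonyl on a nitrogen on an aromatic ring. Going by the values given here, of the measured steps, only the one from compound 1 to compound 2 concerns a substituent on the same six-membered aromatic ring, and it was modest. Among the compounds with values here, no measured step bears on the exchange of the carbonyl link for the sulfonyl link, which is the larger part of the change. A modest shift in this assay towards a higher number is therefore expected, a 2.3-fold higher number from compound 1 to compound 4 (0.36 log units; beyond the scatter), with wide uncertainty. Compound 4 is estimated at 2500 nM in this assay, with a range from 700 nM to 9000 nM.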

Compound 4, half-maximal inhibitory concentration: 770 nM
Beside the measured number, compound 4's estimate is 3.2-fold (0.51 log units) above it, and the stated range covers the measured number.
By their numbers in this assay, from the lowest: compounds 4 and 1 (each within the scatter of the next); then compounds 3 and 2 (each within the scatter of the next).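

In this assay the exchange of linker gives a 1.4-fold lower number from compound 1 to compound 4 (0.15 log units; within the scatter), so this nitrogen carries (4-chlorophenyl)sulfonyl as well as (4-bromophenyl)carbonyl at the resolution of this read-out, and the activity of the series at this level is not tied to the carbonyl link. The step alters the link and the halogen together, so the contribution of each stays unseparated, and two opposing contributions cannot be told from two negligible ones. Nothing at hand offers an explanation for the two linkers reading alike.

Open, from the compounds shown here alone, is how the sulfonyl link behaves with the bromine of compound 1 kept, or with nitro in place of chlorine, which would show whether the step seen with the carbonyl link in a 6.3-fold higher number from compound 1 to compound 2 (0.80 log units; beyond the scatter) carries over to the sulfonyl series. Also open, going by these compounds, are a methoxy group or a dimethylamino group on this aromatic ring, and an ethyl group or a longer chain in place of the methyl on the linking nitrogen.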